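From 4-Chlorophenyl to 3-Fluorophenyl on Compound 3

A few compounds are considered here, and "the series" means these few. Any claim that something is new, unique, unknown or untested is made for them only; others in the source may bear on it.

Measured so far in an ADME assay on HepG2 cells (Homo sapiens) for cytotoxicity, with a stated time of 72 h; a higher number here means that more compound is needed for the effect, a lower number that less compound is needed:
- Compound 1 `O=C(Nc1nc2ccc(Cl)cc2s1)c1cc([N+](=O)[O-])ccc1Cl`: > 27000 nM
- Compound 2 `Cc1cc(NC(=O)c2cc([N+](=O)[O-])ccc2Cl)cc(-c2nc3ccccc3s2)c1O`: > 25000 nM
- Compound 3 `O=C(Nc1nc(-c2ccc(Cl)cc2)cs1)c1cc([N+](=O)[O-])ccc1Cl`: > 27000 nM

All three entries are limits of the assay, not numbers. Compound 3 sits at the limit of > 27000 nM in this assay, at which 2 of the 3 values shown sit, and compound 1 shares that limit. Compound 2 sits at the limit of > 25000 nM in this assay, at which 1 of the 3 values shown sits. Among the compounds with values here, no measured compound therefore gives a true number in this assay, and the three cannot be ranked.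

The next compound is compound 4 `O=C(Nc1nc(-c2cccc(F)c2)cs1)c1cc([N+](=O)[O-])ccc1Cl`, which carries 3-fluorophenyl in place of 4-chlorophenyl on an aromatic carbon of a five-membered aromatic ring with 1 nitrogen and 1 sulfur (3-fluorophenyl in place of 4-chlorophenyl on an aromatic carbon). Within the data shown here, no pair of measured compounds shows what a change like this does, so no step beyond the usual scatter is expected. The expected step is a number no higher from compound 3 to compound 4 (the limit leaves the size open). This expectation rests on compound 3, whose reading of > 27000 nM is a limit. Another limit is the likeliest report for the new compound. For compound 4 the estimated value is 27000 nM, with an expected range from 12000 nM to 50000 nM.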

Compound 4, half-maximal effective concentration: 18000 nM
Compound 4: the middle estimate sits 1.5-fold (0.18 log units) above what was measured; low and high end bracket the measured number.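

Within the data shown here, compound 4 gives the first true number in this assay, which shows that a change on this aromatic carbon of the shared core can bring a reading within the measurable range. Putting 3-fluorophenyl in place of 4-chlorophenyl gives an at least 1.5-fold lower number from compound 3 to compound 4 (0.17 log units; that floor lies within the scatter). That figure is only a floor and the real size of the step stays unknown, because the reading for compound 3 is a limit: the limit of > 27000 nM in this assay, at which 2 of the 4 values shown sit.

This single step changes both the halogen and where it sits on the phenyl ring, so the compounds shown cannot separate the two effects. Going by these compounds, it also remains open how this position would respond to a plain phenyl ring, or to a phenyl ring carrying an amine or a carboxylic acid.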